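A few compounds are considered here, and "the series" means these few. Any claim that something is new, unique, unknown or untested is made for them only; others in the source may bear on it.

Two compounds have been measured so far in a functional assay on MCF7 cells (Homo sapiens) for cytotoxicity, tested at 125 uM; a lower number here means a stronger effect, a higher number a weaker effect of the compound at the concentration tested:

Compound 1 `Cc1ccc(S(=O)(=O)Nc2nnc(SCc3ccccc3)s2)cc1` gives 79%.
Compound 2 `Cc1ccc(S(=O)(=O)Nc2nnc(SCc3ccc(Cl)cc3)s2)cc1` gives 82%.
Compound 3 `Cc1cc(C)c(S(=O)(=O)Nc2nnc(SCc3ccc(Cl)cc3)s2)c(C)c1` is not yet measured.

Compound 2 stands at the higher of the two numbers, but only by a step that lies within the scatter: a number 3 percentage points higher from compound 1 to compound 2 (within the scatter). Within this assay the two compounds therefore cannot be told apart, and neither can be called the stronger.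

Compound 3 keeps the whole of compound 2 except for one exchange: 2,4,6-trimethylphenyl in place of 4-methylphenyl on a sulfonyl sulfur. Going by the values given here, the only measured step, from compound 1 to compound 2, concerns a different part of the molecule, and it lay within the scatter. Among the compounds with values here, no measured step touches the ring on the sulfonyl sulfur, so nothing in these numbers speaks for a shift in either direction beyond the scatter. The expectation for compound 3 is a number close to that of compound 2, with the step estimated as a number 2 percentage points lower from compound 2 to compound 3 (within the scatter). Compound 3 is estimated at 80%, with a range from 62% to 95%.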

Compound 3, a percentage reported as activity, at one concentration (the size of the read-out at that concentration, not a potency): 82%
The estimate for compound 3 lay 2 percentage points below the measured number; the range from low to high includes it.
By their numbers in this assay, from the lowest: compounds 1, 2 and 3 (each within the scatter of the next).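

In this assay, the exchange of 4-methylphenyl for 2,4,6-trimethylphenyl on a sulfonyl sulfur gives no change at the digits printed from compound 2 to compound 3 (within the scatter), and this is the only step shown that touches this part of the molecule. The entering group has 9 heavy atoms where the leaving group has 7, so in this one pair a larger carbon-only aromatic group on the sulfonyl sulfur leaves compound 2 and compound 3 indistinguishable in this read-out, taken at one concentration. No measurement available here offers an explanation for this result, so the pair records only an outcome and not its cause.

Still open, going by these compounds, is whether a group of a different kind on this ring, such as an amine or a carboxylic acid, or a longer alkyl chain in place of the ring on the sulfonyl sulfur, would move the number beyond the scatter. Also open, on these data alone, is whether the same exchange would give a similar result on the core of compound 1, which has hydrogen in place of the chloro group.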